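The source may hold more compounds than are shown below. What is called first, only, known or untested is meant among the compounds shown, and "the series" means these compounds.

In a functional assay on HeLa cells (Homo sapiens) for inhibition (on this read-out higher numbers stand for weaker inhibition and lower numbers for stronger inhibition), compound 1 `Cc1cn(/C=C/C#N)c(=O)[nH]c1=O` gives > 100000 nM, which is a limit of the assay and not a number. Compound 2 `CC(=O)/C=C/n1cc(C)c(=O)[nH]c1=O` likewise gives > 100000 nM in this assay, again a limit and not a number. The two differ by cyano in place of acetyl on a double-bonded chain carbon bound to a double-bonded chain carbon, and the step that the two limits leave unreadable from compound 2 to compound 1 cannot be read, because the limit of > 100000 nM in this assay, at which 2 of the 3 values shown sit, is where both values sit.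

Compound 3 `CC(=O)/C=C/n1c(=O)ccn([C@H]2C[C@H](O)[C@@H](CO)O2)c1=O` is built on a different core; how its core differs from that of compound 2 is not broken down here. In this assay, within the data shown here, compound 3 gives 6000 nM, the only number among the three measured values.

Compound 4 `N#C/C=C/n1c(=O)ccn([C@H]2C[C@H](O)[C@@H](CO)O2)c1=O` has not yet been measured. It differs from compound 3 by cyano in place of acetyl on a double-bonded chain carbon bound to a double-bonded chain carbon, the same change as that from compound 2 to compound 1, made on the core of compound 3. Since that earlier step is unreadable, the expectation rests only on the value of compound 3 in this assay, 6000 nM, and the estimated step is a 1.7-fold higher number from compound 3 to compound 4 (0.22 log units; within the scatter), held close to no change. Compound 4 is therefore expected to give about 10000 nM in this assay, with a likely range from 2500 nM to 40000 nM.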

Compound 4, half-maximal inhibitory concentration: 100000 nM
The estimate for compound 4 lay 10-fold (1.00 log units) below the measured number, and the stated range ends below it.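

In this assay, cyano in place of acetyl on the core of compound 3 gives a 17-fold higher number from compound 3 to compound 4 (1.22 log units; beyond the scatter), so on this core the change clearly weakens inhibition. The same change on the core of compound 2 cannot be read, because both values there are limits of the assay and not numbers: the limit of > 100000 nM in this assay, at which 2 of the 4 values shown sit. The series therefore holds only one readable case of this change, which shows its size on one core but not whether that size carries over from one core to another.

Still open, as far as these compounds go, is how other groups in the same place on the core of compound 3 would read, such as an amine, a carboxylic acid or a methyl ester in place of acetyl. Also open, from the compounds shown here alone, is what a longer chain carrying the acetyl group would give on that core, and how far inhibition depends on the 2-acetylethenyl group at all.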